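Shortening an Alkyl Chain on a Triazole Core

The source may report more compounds than this note shows. Statements on the series, on what has been measured and on what is new or still open speak of the compounds shown alone.

Measured so far:
compound 1 `CCCCCc1cn(C/C=C(/C)CCC=C(C)C)nn1` – 5.45
compound 2 `CCCc1cn(C/C=C(/C)CC/C=C(\C)CCC=C(C)C)nn1` – 6.5
compound 3 `CCCCCCCCc1cn(C/C=C(/C)CC/C=C(\C)CCC=C(C)C)nn1` – 8.76

In a physicochemical assay for lipophilicity, measured as octanol-water partition (a higher number here means a more lipophilic compound, a lower number a more polar compound), compound 3 stands highest of the three numbers shown. Its nearest neighbour is compound 2, and the difference between them is a single measured step, a number 2.26 log units higher from compound 2 to compound 3 (beyond the scatter), which is a large one and well beyond the usual scatter. Compound 1 lies furthest away, with a value far below that of compound 3.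

Compound 4 `CCCCCc1cn(C/C=C(/C)CC/C=C(\C)CCC=C(C)C)nn1` has not yet been measured. It differs from compound 3 in one place: hydrogen in place of propyl on a saturated chain carbon, five bonds along the chain from an aromatic carbon. The step from compound 2 to compound 3 is the only measured one that bears on this change, since it also alters the length of the same saturated chain, and it moved the value by a number 2.26 log units higher from compound 2 to compound 3 (beyond the scatter). Removing propyl is a smaller change than adding pentyl, so a step in the opposite direction, and a smaller one, is what the shown numbers suggest.

For compound 4 the estimate is therefore 7.4, with a range from 6.9 to 7.9, meaning an expected step of a number 1.36 log units lower from compound 3 to compound 4 (beyond the scatter) in this assay.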

Compound 4, partition coefficient: 7.5
The estimate for compound 4 lay 0.10 log units below the measured number; measured number inside the range.
By their numbers in this assay, from the lowest: compound 1; then compound 2; then compound 4; then compound 3.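

With compound 4 the same saturated chain can now be compared at a third length: in this assay, hydrogen in place of propyl on a saturated chain carbon, five bonds along the chain from an aromatic carbon, gives a number 1.26 log units lower from compound 3 to compound 4 (beyond the scatter), while ethyl in place of hydrogen, three bonds along the chain from an aromatic carbon, gives a number 1.00 log units higher from compound 2 to compound 4 (beyond the scatter). Across compound 2, compound 4 and compound 3, the value therefore rises in order with each lengthening of this chain, and none of these compounds goes against that order. Compound 4 also opens a comparison on the other side of the shared core, where 3-methylbut-2-en-1-yl in place of hydrogen on a saturated chain carbon bound to a double-bonded chain carbon gives a number 2.05 log units higher from compound 1 to compound 4 (beyond the scatter).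

No supporting information accounts for the size of any of these steps. Still open, as far as these compounds go, is whether an amine or a carboxylic acid in place of propyl would fall in line with these chains, and whether a chain longer than that of compound 3 would continue the rise.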